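Swapping the branched chain for dicyclobutylmethyl

The source may hold more compounds than are shown below. What is called first, only, known or untested is meant among the compounds shown, and "the series" means these compounds.

- compound 1 `CC(C)C(Nc1nc(Cl)nc2c1ncn2[C@H]1[C@H](O)[C@H](O)[C@]2(CO)C[C@H]12)C(C)C`: > 100000 nM (a limit)
- compound 2 `CC(C)(O)[C@@H](Nc1nc(Cl)nc2c1ccn2[C@H]1[C@H](O)[C@H](O)[C@]2(CO)C[C@H]12)C1CC1`: > 100000 nM (a limit)
- compound 3 `O[C@@H]1[C@H](O)[C@@H]2C[C@@H]2[C@H]1n1ccc2c(NC(C3CC3)C3CC3)nc(I)nc21`: 100000 nM

These three compounds were tested in an ADME assay on Vero 76 cells (Chlorocebus sabaeus) for cytotoxicity, read by microscopy; a lower number here means that less compound is tolerated, a higher number that more compound is tolerated. Compound 1 has only a limit, not an exact number, and it stands with the limit of > 100000 nM in this assay, at which 2 of the 3 values shown sit. Compound 4 `OC[C@@]12C[C@@H]1[C@@H](n1cnc3c(NC(C4CCC4)C4CCC4)nc(Cl)nc31)[C@H](O)[C@@H]2O` differs from compound 1 in one place, on a nitrogen on an aromatic ring: dicyclobutylmethyl in place of 1-isopropyl-2-methylpropyl on a nitrogen on an aromatic ring. Among the compounds with values here, no measured pair of compounds shows the effect of this change directly. Within the data shown here, compound 3 gives 100000 nM, which is the only exact number available as a guide. The expected change is small and no larger than the scatter, an estimated a number no higher from compound 1 to compound 4 (the limit leaves the size open). For compound 4 the estimated value is 100000 nM, with an expected range from 40000 nM to 200000 nM.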

Compound 4, half-maximal cytotoxic concentration: 50000 nM
For compound 4 the middle estimate is 2.0-fold (0.30 log units) above the measured one, and the stated range covers the measured number.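

With dicyclobutylmethyl in this place, the core of compound 1 now has an exact number rather than a limit, and the change gives an at least 2.0-fold lower number from compound 1 to compound 4 (0.30 log units; that floor lies within the scatter) in this assay. This step is only a floor, so its true size could be larger, and it may or may not exceed the usual scatter. Compound 1 holds only a limit of the assay: the limit of > 100000 nM in this assay, at which 2 of the 4 values shown sit.

Still open, as far as these compounds go, is how far the number for compound 1 truly lies from that of compound 4. Also open, from the compounds shown here alone, is how a longer straight chain or a chain ending in an amine would read in this assay when placed on this nitrogen.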